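A few compounds are considered here, and "the series" means these few. Any claim that something is new, unique, unknown or untested is made for them only; others in the source may bear on it.

Compound 1 `Cn1c(=O)[nH]c2c(cnn2-c2ccccc2Br)c1=N`: 6%
Compound 2 `Cn1c(=O)[nH]c2c(cnn2-c2ccccc2N)c1=N`: 0%
Compound 3 `Cn1c(=O)[nH]c2c(cnn2-c2cccc([N+](=O)[O-])c2)c1=N`: 2%

In an assay on membranes from brain for binding affinity to adenosine receptor A1 (Rattus norvegicus), read by radioligand binding, tested at 20 uM (a higher number here means more inhibition at the concentration tested (going by the name of the read-out), a lower number less inhibition), compound 2 gives 0%, the lowest of the three numbers shown, yet compound 3 and compound 1 both lie within the scatter of it, so the three compounds cannot be told apart on these numbers. Compound 4 `Cn1c(=O)[nH]c2c(cnn2-c2ccccc2Cl)c1=N` is not yet measured. It differs from compound 2 in one place: chloro in place of amino on an aromatic carbon. For the measured compounds named here, only one measured step touches the same position, the step of a number 6 percentage points lower from compound 1 to compound 2 (within the scatter), in which bromo gave way to amino; that step stayed within the scatter. Compound 4 carries a halogen there again, as compound 1 did, so the change from compound 2 to compound 4 runs the step back toward a halogen, and no step beyond the scatter is expected in this assay. Compound 4 is therefore expected to give about 5%, between -4% and 15%, which means an expected step of a number 5 percentage points higher from compound 2 to compound 4 (within the scatter).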

Compound 4, a percentage reported as inhibition, at one concentration (the size of the read-out at that concentration, not a potency): 7%
The estimate for compound 4 lay 2 percentage points below the measured number, and the stated range covers the measured number.
By their numbers in this assay, from the lowest: compounds 2, 3, 1 and 4 (each within the scatter of the next).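

In this assay, chloro in place of amino gives a number 7 percentage points higher from compound 2 to compound 4 (within the scatter) and chloro in place of bromo gives a number 1 percentage points higher from compound 1 to compound 4 (within the scatter) at the same aromatic carbon. The earlier step covered only bromo and amino, whereas these results put a second halogen at that carbon and close a set of three compounds, so amino, bromo and chloro cannot be told apart there on these numbers. No independent measurement bears on why this position behaves this way.

It remains open whether a methoxy group, a carboxylic acid or a longer chain at the same carbon would give a number beyond the scatter of these compounds. On these data alone, it is equally open whether any change to the shared core would move the number at this concentration.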